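The source may hold more compounds than are shown below. What is called first, only, known or untested is meant among the compounds shown, and "the series" means these compounds.

Working notes on the series. Compound 1 `O=C1Nc2ccc(Cl)cc2/C1=C\c1c(Cl)n(CCCc2ccccc2)c2ccccc12` is tested in a functional assay on cells (Cancer cell lines, Homo sapiens) for cytotoxicity, with a stated time of 48 h (a lower number here means a stronger inhibitor of growth, a higher number a weaker inhibitor of growth), where compound 1 gives 2000 nM. Among the compounds with values here, the only other measured member, compound 2 `COc1cc2c(c(OC)c1OC)/C(=C\c1c(Cl)[nH]c3ccccc13)C(=O)N2`, gives 1170 nM in this assay; the two numbers sit within the usual scatter of each other, so compound 1 stands level with compound 2 rather than apart from it, and no direction of change can be read from that pair.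

Compound 3 `O=C1Nc2ccccc2/C1=C\c1c(Cl)n(CCCc2ccccc2)c2ccccc12` is not yet measured in this assay. Compound 3 differs from compound 1 by hydrogen in place of chloro on an aromatic carbon. Within the data shown here, no measured pair in the set shows this kind of change, so its size cannot be taken from data here. Loss of a single chlorine at this place is expected to leave the number about where compound 1 stands, with no step beyond the scatter. Compound 3 is therefore estimated at 2500 nM, range 1000 nM to 6000 nM. The expected step of a 1.3-fold higher number from compound 1 to compound 3 (0.10 log units; within the scatter) is small.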

Compound 3, concentration for 50% growth inhibition: 19100 nM
For compound 3 the middle estimate is 7.6-fold (0.88 log units) below the measured one; the measured number lies above the stated range.
By their numbers in this assay, from the lowest: compounds 2 and 1 (each within the scatter of the next); then compound 3.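

In this assay, hydrogen in place of chloro on this aromatic carbon, meta to a fused ring and para to a fused ring, gives a 9.6-fold higher number from compound 1 to compound 3 (0.98 log units; beyond the scatter). Within the data shown here, this is the first step that differs in one place, and it shows that the chloro at this position is not interchangeable with hydrogen in this pair, with compound 1 the stronger inhibitor of growth. Nothing available here accounts for the size of this step.

As far as these compounds go, whether fluoro, bromo, methyl, methoxy or an amine at this position would keep the number near that of compound 1 or leave it near that of compound 3 remains open. Also open, from the compounds shown here alone, is whether the same exchange of chloro for hydrogen gives a step of similar size on any other core.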